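Bromo to cyano across a thioether and a sulfone pair

The source may hold more compounds than are shown below. What is called first, only, known or untested is meant among the compounds shown, and "the series" means these compounds.

Measured compounds:
compound 1 `N#Cc1c(N)cccc1Sc1cccc(Br)c1` gives 53000 nM
compound 2 `N#Cc1cccc(Sc2cccc(N)c2C#N)c1` gives 80000 nM
compound 3 `N#Cc1c(N)cccc1S(=O)(=O)c1ccc(Br)cc1` gives > 200000 nM

In a functional assay on MT4 cells (Homo sapiens) for cytotoxicity (a lower number here means a stronger inhibitor, a higher number a weaker inhibitor), the change from compound 1 to compound 2 is cyano in place of bromo on an aromatic carbon, and the measured step is a 1.5-fold higher number from compound 1 to compound 2 (0.18 log units; within the scatter). For compound 3 the value in this assay is a limit only, namely (the limit of > 200000 nM in this assay, at which 1 of the 3 values shown sits). How the core of compound 3 differs from the core of compound 1 is not broken down here.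

Compound 4 `N#Cc1ccc(S(=O)(=O)c2cccc(N)c2C#N)cc1` is not yet measured. It differs from compound 3 by cyano in place of bromo on an aromatic carbon, the same kind of change as between compound 1 and compound 2, but with a different place: meta to a large group there, para to a large group here. The expected step is a step that the limit leaves unreadable from compound 3 to compound 4, resting on the small earlier step of a 1.5-fold higher number from compound 1 to compound 2 (0.18 log units; within the scatter) and on the limit (the limit of > 200000 nM in this assay, at which 1 of the 3 values shown sits). Compound 4 is therefore estimated at 260000 nM in this assay, between 150000 nM and 450000 nM, and is expected to come back as a limit again.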

Compound 4, half-maximal inhibitory concentration: > 200000 nM
Compound 4: no number, only a limit; the forecaster's own chance of this, stated with the estimate: 85%; the middle value does not contradict the limit.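

In this assay compound 3 and compound 4 are both recorded only as limits, so no step can be read between them: the limit of > 200000 nM in this assay, at which 2 of the 4 values shown sit.

The compounds shown leave open whether cyano in place of bromo changes the number at all when para to a large group.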